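This account rests on a few compounds, and the source may have more. Where it says the series, first, only, none or still open, it means among the compounds named here.

Measured so far:
compound 1 `O=C(Nc1cccc(-n2cc(-c3ccncc3)c(-c3ccc(Cl)c(O)c3)n2)c1)Nc1cccc(C(F)(F)F)c1` — > 32500 nM
compound 2 `COc1cc(-c2nn(-c3cccc(NC(=O)Nc4cc(C(F)(F)F)cc(C(F)(F)F)c4)c3)cc2-c2ccncc2)ccc1Cl` — 23700 nM

Going by the values given here, in a functional assay on IGROV-1 cells (Homo sapiens) for inhibition, read by sulforhodamine B assay, with a stated time of 48 h (on this read-out higher numbers stand for lower toxicity in this test and lower numbers for higher toxicity in this test), compound 2 gives 23700 nM, the only actual number among the two values shown; the toxicity is weak. For compound 1 the result is > 32500 nM, a limit of the assay rather than a number. (the limit of > 32500 nM in this assay, at which 1 of the 2 values shown sits). Among the compounds with values here, no two measured compounds differ in a single place, so no step size is known from, and the two values are merely side by side: one weak number and one limit.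

Compound 3 `O=C(Nc1cccc(-n2cc(-c3ccncc3)c(-c3ccc(Cl)c(O)c3)n2)c1)Nc1cc(C(F)(F)F)cc(C(F)(F)F)c1` differs from compound 2 in one place: hydrogen in place of methyl on an oxygen on an aromatic ring, that is, methoxy to hydroxy on the 4-chloro-3-methoxyphenyl ring, which becomes 4-chloro-3-hydroxyphenyl. The rest of the molecule, including the bis-trifluoromethyl-substituted urea end, is unchanged.

Within the data shown here, with no measured step to lean on, the step is expected to be a 1.3-fold higher number from compound 2 to compound 3 (0.10 log units; within the scatter), within the scatter, and there is a fair chance that only a limit is reported. Compound 3 is expected to give about 30000 nM, with a range of 12000 nM to 70000 nM.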

Compound 3, concentration lethal to 50% of the cells: 38200 nM
For compound 3 the middle estimate is 1.3-fold (0.10 log units) below the measured one; the range from low to high includes it.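

In this assay the series now has its first readable step, a 1.6-fold higher number from compound 2 to compound 3 (0.21 log units; within the scatter), for hydrogen in place of methyl on an oxygen on an aromatic ring. With the rest of the molecule unchanged, this read-out does not tell methoxy from hydroxy on this ring, and both compounds show weak toxicity in this test. The other new step, trifluoromethyl in place of hydrogen on an aromatic carbon, cannot be read because compound 1 carries a limit: the limit of > 32500 nM in this assay, at which 1 of the 3 values shown sits.

The compounds shown leave open whether a longer chain on this oxygen, such as ethoxy, or an amine in place of the hydroxy, would keep the value in the same range. Going by these compounds, the size of the trifluoromethyl step also remains open, since a limit is not a number.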